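Cyclopropylmethyl Amide Swap on an Iodobenzyl Adenosine Analogue

A few compounds are considered here, and "the series" means these few. Any claim that something is new, unique, unknown or untested is made for them only; others in the source may bear on it.

Measured compounds in an assay on CHO cells for displacement of a labelled ligand from adenosine receptor A3 (Homo sapiens); a higher number here means a weaker inhibitor, a lower number a stronger inhibitor:
Compound 1, `CNc1nc(Cl)nc2c1ncn2[C@@H]1O[C@H](C(=O)NC2CC2)[C@@H](O)[C@H]1O`, gives 2.82 nM.
Compound 2, `CNc1nc(Cl)nc2c1ncn2[C@@H]1O[C@H](C(=O)NCC2CC2)[C@@H](O)[C@H]1O`, gives 1.1 nM.
Compound 3, `O=C(NC1CC1)[C@H]1O[C@@H](n2cnc3c(NCc4cccc(I)c4)nc(Cl)nc32)[C@H](O)[C@@H]1O`, gives 2.95 nM.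

Compound 2 arises from compound 1 by cyclopropylmethyl in place of cyclopropyl on an amide-type nitrogen, and this step was a 2.6-fold lower number from compound 1 to compound 2 (0.41 log units; beyond the scatter). Compound 3 differs from compound 1 by 3-iodophenyl in place of hydrogen on a saturated chain carbon bound to a nitrogen on an aromatic ring, a step of a 1.0-fold higher number from compound 1 to compound 3 (0.02 log units; within the scatter). Compound 4, `O=C(NCC1CC1)[C@H]1O[C@@H](n2cnc3c(NCc4cccc(I)c4)nc(Cl)nc32)[C@H](O)[C@@H]1O`, is not yet measured; it arises from compound 3 by cyclopropylmethyl in place of cyclopropyl on an amide-type nitrogen. The place of this change reads the same as for the step from compound 1 to compound 2, so it is the same change, made this time on the core that carries the 3-iodobenzyl group. The pair of compounds 1 and 3 shows that this core exchange left the number in this assay essentially where it was.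

Going by the values given here, compound 4 is expected to show a 2.5-fold lower number from compound 3 to compound 4 (0.39 log units; beyond the scatter) in this assay, a step of the same order as the one from compound 1 to compound 2, because that earlier step was a 2.6-fold lower number from compound 1 to compound 2 (0.41 log units; beyond the scatter) and the core of compound 3 has so far tracked compound 1 closely. The estimated value for compound 4 is 1.2 nM, with a range from 0.5 nM to 3 nM.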

Compound 4, inhibition constant: 3.63 nM
The estimate for compound 4 lay 3.0-fold (0.48 log units) below the measured number; the whole stated range lies below it.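

On the core that carries the 3-iodobenzyl group, cyclopropylmethyl in place of cyclopropyl gave a 1.2-fold higher number from compound 3 to compound 4 (0.09 log units; within the scatter) in this assay, so the lower number seen on the core of compound 1 did not carry over: the same change on two cores in this assay, a 2.6-fold lower number (0.41 log units; beyond the scatter) from compound 1 to compound 2 and a 1.2-fold higher number (0.09 log units; within the scatter) from compound 3 to compound 4, 3.2-fold (0.50 log units) apart, beyond the scatter of two such steps. Read the other way, the 3-iodophenyl group left the number unchanged within the scatter on the cyclopropyl amide but gave a 3.3-fold higher number from compound 2 to compound 4 (0.52 log units; beyond the scatter) on the cyclopropylmethyl amide, so the two changes do not simply add: the same change on two cores in this assay, a 1.0-fold higher number (0.02 log units; within the scatter) from compound 1 to compound 3 and a 3.3-fold higher number (0.52 log units; beyond the scatter) from compound 2 to compound 4, 3.2-fold (0.50 log units) apart, beyond the scatter of two such steps. Among these compounds, the outcome of each change therefore depends on the group present at the other place, but the data do not show why, and two cores cannot predict the result on a further core.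

The compounds shown leave open whether a plain benzyl group in place of the 3-iodobenzyl group would also remove the step seen between compound 1 and compound 2. They also leave open how an ethyl group or a longer chain on the amide-type nitrogen would behave on either core.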